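From 3,4-dichlorophenyl to a pentyl chain

A few compounds are considered here, and "the series" means these few. Any claim that something is new, unique, unknown or untested is made for them only; others in the source may bear on it.

Values in an ADME assay on MDCK cells (Canis lupus familiaris) for cytotoxicity, read by MTT assay, with a stated time of 48 h; a lower number here means that less compound is tolerated, a higher number that more compound is tolerated:
- compound 1 `CC(C)(C)c1ccc(-c2cn(CC3=C(Cl)c4ccc(-c5cccs5)nc4CC3)nn2)cc1`: 172 ug/mL
- compound 2 `Fc1ccc(-c2cn(CC3=C(Cl)c4ccc(-c5cccs5)nc4CC3)nn2)cc1`: 100 ug/mL
- compound 3 `ClC1=C(Cn2cc(-c3ccc(Cl)c(Cl)c3)nn2)CCc2nc(-c3cccs3)ccc21`: > 300 ug/mL (a limit, not a number)

Compound 3 stands at the limit of > 300 ug/mL in this assay, at which 1 of the 3 values shown sits, so its true value is not known. Compound 4 `CCCCCc1cn(CC2=C(Cl)c3ccc(-c4cccs4)nc3CC2)nn1` carries pentyl in place of 3,4-dichlorophenyl on an aromatic carbon. The closest guides are the two measured swaps at this same place, both of which end at the 3,4-dichlorophenyl group. The first is an at least 1.7-fold higher number from compound 1 to compound 3 (0.24 log units; that floor lies within the scatter), and the second is an at least 3.0-fold higher number from compound 2 to compound 3 (0.47 log units; beyond the scatter). The groups compared there also differ little from each other, as a 1.7-fold lower number from compound 1 to compound 2 (0.24 log units; within the scatter) shows. Among the compounds with values here, no measured compound carries a chain here, so this comparison is loose. Leaving compound 3 should therefore bring a modest move to a lower number in this assay, meaning less compound tolerated. The expected step is an at least 2.0-fold lower number from compound 3 to compound 4 (0.30 log units; that floor lies within the scatter). The estimate for compound 4 is 150 ug/mL, with an expected range of 60 ug/mL to 320 ug/mL.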

Compound 4, half-maximal cytotoxic concentration: 50 ug/mL
For compound 4 the middle estimate is 3.0-fold (0.48 log units) above the measured one; the whole stated range lies above it.
By their numbers in this assay, from the lowest: compounds 4, 2 and 1 (each within the scatter of the next, the first and the last beyond it). At a limit, above all of these: compound 3.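

In this assay, putting pentyl in place of an aromatic ring at this position gives an at least 6.0-fold lower number from compound 3 to compound 4 (0.77 log units; beyond the scatter) and a 3.4-fold lower number from compound 1 to compound 4 (0.54 log units; beyond the scatter), but a 2.0-fold lower number from compound 2 to compound 4 (0.30 log units; within the scatter). Within the data shown here, this is the first chain seen here, and it shows that losing the ring does not by itself set the number: pentyl separates from the 3,4-dichlorophenyl and 4-(tert-butyl)phenyl groups, yet not from the 4-fluorophenyl group of compound 2. The step from compound 3 gives only a minimum size because compound 3 stands at a limit: the limit of > 300 ug/mL in this assay, at which 1 of the 4 values shown sits.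

One pentyl compound cannot show whether chain length matters, which a propyl or an octyl chain would test. On these data alone, whether a chain ending in an amine or a carboxylic acid would fall near compound 4 also remains open.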